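From 2-hydroxyethyl to 1-hydroxyethyl on a shared core

This account rests on a few compounds, and the source may have more. Where it says the series, first, only, none or still open, it means among the compounds named here.

Measured so far:
Compound 1 `OCc1cn(Cc2ccc(Cl)cc2)c2ccccc12`: > 31600 nM
Compound 2 `OCCc1cn(Cc2ccc(Cl)cc2)c2ccccc12`: > 31600 nM

The test used here is an ADME assay on T29 cells (Homo sapiens) for cytotoxicity, read by sulforhodamine B assay, with a stated time of 3 days; on this read-out lower numbers stand for stronger inhibition and higher numbers for weaker inhibition. In it, compound 2 gives > 31600 nM, which is a limit of the assay and not a number. Compound 1 gives > 31600 nM, also a limit. Compound 3 `CC(O)c1cn(Cc2ccc(Cl)cc2)c2ccccc12` has the same atoms as compound 2, joined differently: 1-hydroxyethyl in place of 2-hydroxyethyl on an aromatic carbon. For the measured compounds named here, the only measured step that bears on this change is a step that the two limits leave unreadable from compound 1 to compound 2, so it offers no size to carry over. Both measured compounds sit at the limit of > 31600 nM in this assay, at which 2 of the 2 values shown sit, and this shared limit is the sole basis for expecting no step beyond the usual scatter, in either direction. The expected step is a step that the limit leaves unreadable from compound 2 to compound 3. The estimate for compound 3 is 40000 nM. The expected range runs from 16000 nM to 100000 nM, and another limit is the likeliest report.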

Compound 3, half-maximal inhibitory concentration: > 31500 nM
Compound 3: no number, only a limit; the forecaster's own chance of this, stated with the estimate: 80%; the middle value is on the limit's open side.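

Compound 3 gives only a limit, as do compound 1 and compound 2, so no step among these three compounds can be read. From the compounds shown here alone, what stays open is whether 1-hydroxyethyl and 2-hydroxyethyl differ in this assay at all, since the true values of all three lie beyond their limits.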